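Swapping nitro for carbamoyl on a kinase binder

A few compounds are considered here, and "the series" means these few. Any claim that something is new, unique, unknown or untested is made for them only; others in the source may bear on it.

Measured compounds:
Compound 1, `CCCS(=O)(=O)Nc1ccc(F)c(C(=O)c2n[nH]c3ncc(-c4ccccc4O)cc23)c1F`, gives 9%.
Compound 2, `CCCS(=O)(=O)Nc1ccc(F)c(C(=O)c2n[nH]c3ncc(-c4ccc([N+](=O)[O-])cc4)cc23)c1F`, gives 4.2%.

In an assay for binding affinity to dual specificity mitogen-activated protein kinase kinase 4 (Homo sapiens), read by KINOMEscan, tested at 100 nM (a lower number here means a stronger effect, a higher number a weaker effect of the compound at the concentration tested), compound 1 and compound 2 both give low numbers, and the step of a number 4.8 percentage points lower from compound 1 to compound 2 (within the scatter) lies within the scatter, so the two compounds sit at the same level on this read-out; neither can be said to show the stronger effect at the concentration tested. Compound 3, `CCCS(=O)(=O)Nc1ccc(F)c(C(=O)c2n[nH]c3ncc(-c4ccc(C(N)=O)cc4)cc23)c1F`, has not yet been measured. It differs from compound 2 in one place: carbamoyl in place of nitro on an aromatic carbon. For the measured compounds named here, the only measured step that bears on this change is the one at the same position, a number 4.8 percentage points lower from compound 1 to compound 2 (within the scatter), where a 4-nitrophenyl replaced a 2-hydroxyphenyl without moving the number beyond the scatter. On that basis the replacement of nitro by carbamoyl is expected to leave this assay essentially unchanged, with the step of a number 3.8 percentage points higher from compound 2 to compound 3 (within the scatter) expected to stay within the scatter. Compound 3 is therefore estimated to give 8% in this assay, with a range from 1.5% to 30%.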

Compound 3, a percentage reported as activity, at one concentration (the size of the read-out at that concentration, not a potency): 0.15%
Compound 3: the middle estimate sits 7.9 percentage points above what was measured; measured number below the stated range.
By their numbers in this assay, from the lowest: compounds 3, 2 and 1 (each within the scatter of the next).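

In this assay, carbamoyl in place of nitro gives a number 4.1 percentage points lower from compound 2 to compound 3 (within the scatter), so the number stays at the same low level even though carbamoyl carries a hydrogen-bond donor and nitro carries none. The comparison with the hydroxyl-bearing ring reads the same way, with a number 8.9 percentage points lower from compound 1 to compound 3 (within the scatter), so 2-hydroxyphenyl, 4-nitrophenyl and 4-carbamoylphenyl at this position now sit at one level, and none of the three can be called the strongest binder. The data shown give no explanation for why these different groups sit so close together.

On these data alone, since this assay reads each compound at a single concentration and all three numbers are low, it remains open whether the three would separate if tested at lower concentrations. As far as these compounds go, it is also open whether the same level would hold with a carboxylic acid or an amine in place of carbamoyl, para to the large group, or with a longer chain on the amide nitrogen.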